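Replacing the 4-methylpiperidin-1-yl group of compound 2

The compounds below may be only part of what the source reports. "The series", "measured", "known", "first", "only" and "open" are said of these compounds alone.

In a functional assay on MDA-MB-231 cells (Homo sapiens) for cytotoxicity, read by MTT assay, with a stated time of 72 h (on this read-out lower numbers stand for stronger inhibition and higher numbers for weaker inhibition), compound 1 `CN(C)Cc1ccc2nc(NC(=O)N/N=C/c3cn(Cc4ccccc4Cl)c4ccccc34)sc2c1` gives 1180 nM and compound 2 `CC1CCN(Cc2ccc3nc(NC(=O)N/N=C/c4c[nH]c5ccccc45)sc3c2)CC1` gives 2460 nM. Compound 2 therefore holds the higher of the two numbers, and this gap lies beyond the usual scatter. The two compounds differ in more than one place, so the gap cannot be assigned to any single group. Compound 3 `CN(C)Cc1ccc2nc(NC(=O)N/N=C/c3c[nH]c4ccccc34)sc2c1` has dimethylamino in place of 4-methylpiperidin-1-yl on a saturated chain carbon bound to an aromatic carbon. Within the data shown here, no measured pair shows this change alone, although compound 1 carries the same (dimethylamino)methyl group and gives 1180 nM. In this assay the expected result is a 1.0-fold higher number from compound 2 to compound 3 (0.01 log units; within the scatter), with no step beyond the scatter and no firm direction. For compound 3 the estimated value is 2500 nM, with an expected range from 1000 nM to 6000 nM.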

Compound 3, half-maximal inhibitory concentration: 1190 nM
The estimate for compound 3 lay 2.1-fold (0.32 log units) above the measured number; the measured number falls inside the stated range.
By their numbers in this assay, from the lowest: compounds 1 and 3 (each within the scatter of the next); then compound 2.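

On the saturated chain carbon bound to an aromatic carbon, dimethylamino in place of 4-methylpiperidin-1-yl now stands alone in a measured pair, and in this assay it gives a 2.1-fold lower number from compound 2 to compound 3 (0.32 log units; beyond the scatter) as a modest step. On the aromatic nitrogen, hydrogen in place of 2-chlorobenzyl gives a 1.0-fold higher number from compound 1 to compound 3 (0.00 log units; within the scatter) and so compound 1 and compound 3 cannot be told apart on this read-out. Nothing measured here accounts for either result.

The compounds shown leave open whether a morpholine or a pyrrolidine on that saturated chain carbon would stand closer to dimethylamino or to 4-methylpiperidin-1-yl. They also leave open whether 2-chlorobenzyl on the aromatic nitrogen would give the same result alongside 4-methylpiperidin-1-yl, and whether a methyl or an unsubstituted benzyl there would differ from hydrogen.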